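Amide variation on the shared core: efficacy in K-ATP functional assay

A few compounds are considered here, and "the series" means these few. Any claim that something is new, unique, unknown or untested is made for them only; others in the source may bear on it.

Measured so far:
compound 1, `COCC(=O)Nc1c(C(O)(C(F)(F)F)C(F)(F)F)ccc2ccccc12`, 93%
compound 2, `O=C(Nc1c(C(O)(C(F)(F)F)C(F)(F)F)ccc2ccccc12)c1cccc(Cl)c1`, 84%
compound 3, `N#Cc1cccc(C(=O)Nc2c(C(O)(C(F)(F)F)C(F)(F)F)ccc3ccccc23)c1`, 96%

The three compounds share one core and differ only in the group on the carbonyl carbon of the amide. In a functional assay (Sus scrofa) with sulfonylurea receptors; K-ATP channels (Homo sapiens) as the target (a lower number here means a smaller maximal response, a higher number a larger maximal response), compound 3 gives the highest of the three numbers; compound 1 is the nearest, and a number 3 percentage points higher from compound 1 to compound 3 (within the scatter), so the two are not separated. Compound 2 is the furthest, and a number 12 percentage points higher from compound 2 to compound 3 (beyond the scatter). The step of a number 9 percentage points lower from compound 1 to compound 2 (within the scatter) is likewise not separated from the scatter.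

Compound 4, `O=C(Nc1c(C(O)(C(F)(F)F)C(F)(F)F)ccc2ccccc12)c1ccc(Cl)cc1`, is not yet measured. It differs from compound 3 as follows: 4-chlorophenyl in place of 3-cyanophenyl on a carbonyl carbon. Among the compounds with values here, the one measured step that bears on this change is the replacement of chloro by cyano on the aromatic carbon, where a number 12 percentage points higher from compound 2 to compound 3 (beyond the scatter). Within the data shown here, compound 4 reverses that exchange, chloro again in place of cyano, though the chloro now sits in the 4-position of the phenyl rather than the 3-position of compound 2; no measured pair tells how that shift of position acts. A modest fall toward the number of compound 2 is therefore the expectation, with wide uncertainty from the unmeasured positional shift: a number 10 percentage points lower from compound 3 to compound 4 (within the scatter) is the expected step. For compound 4 in this assay the estimate is 86%, with a range of 72% to 97%.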

Compound 4, largest response reached (reported as efficacy), in percent of the reference or control that the assay uses: 99%
For compound 4 the middle estimate is 13 percentage points below the measured one, and the stated range ends below it.
By their numbers in this assay, from the lowest: compounds 2, 1, 3 and 4 (each within the scatter of the next, the first and the last beyond it).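

In this assay, the exchange of 3-chlorophenyl for 4-chlorophenyl on the carbonyl carbon gives a number 15 percentage points higher from compound 2 to compound 4 (beyond the scatter), so the presence of a chlorinated phenyl does not by itself go with the number of compound 2; the two isomeric groups are separated. Against 3-cyanophenyl, 4-chlorophenyl gives a number 3 percentage points higher from compound 3 to compound 4 (within the scatter), and against methoxymethyl it gives a number 6 percentage points higher from compound 1 to compound 4 (within the scatter), so this position accepts all three of these groups without separation, and compound 2 stands apart from compound 3 and compound 4 but not from compound 1. No measurement at hand accounts for the difference between the two chlorophenyl groups.

The series leaves open whether the same exchange matters for other substituents, as a pair of 3-cyanophenyl and 4-cyanophenyl would show, and whether the result holds for 4-fluorophenyl or 4-methoxyphenyl. Also open, from the compounds shown here alone, is how the maximal response changes with a group of a different kind on the carbonyl carbon, such as cyclohexyl, a longer ether chain, or a phenyl carrying a carboxylic acid or an amine.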